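The source may hold more compounds than are shown below. What is called first, only, known or untested is meant among the compounds shown, and "the series" means these compounds.

Series notes. Compound 1 `COC(=O)/C=C/c1cccc(N(Cc2ccccc2)C(=O)C2CCCCC2)c1` is the parent of the set. In an assay on isolated protein with Bile acid receptor (Homo sapiens) as the target (on this read-out higher numbers stand for an effect only at larger amounts of compound and lower numbers for an effect already at smaller amounts), compound 1 gives > 1000 nM, which is a limit of the assay rather than a number. Compound 2 `COC(=O)/C=C/c1cccc(N(Cc2cccc(OC)c2)C(=O)C2CCCCC2)c1` carries methoxy in place of hydrogen on an aromatic carbon. In this assay compound 2 gives > 1000 nM, again a limit and not a number. For the measured compounds named here, the step that the two limits leave unreadable from compound 1 to compound 2 is thus unreadable; both values sit at the limit of > 1000 nM in this assay, at which 2 of the 2 values shown sit, so no measured step yields a usable size. Compound 3 `COC(=O)/C=C/c1cccc(N(Cc2ccc(-c3cc(Cl)ccc3OC)cc2)C(=O)C2CCCCC2)c1` is not yet measured; it differs from compound 1 by 5-chloro-2-methoxyphenyl in place of hydrogen on an aromatic carbon. Going by the values given here, the only measured step also replaces hydrogen on an aromatic carbon but gives no readable size, so no direction in this assay can be drawn from it, and a step within the scatter is as plausible as one beyond it. The expected step from compound 1 to compound 3 is an at least 1.2-fold lower number from compound 1 to compound 3 (0.09 log units; that floor lies within the scatter). Compound 3 is estimated in this assay at 800 nM, within 100 nM to 5000 nM.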

Compound 3, half-maximal effective concentration: 233 nM
Estimate against measurement, compound 3: 3.4-fold (0.54 log units) above; the range from low to high includes it.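

In this assay, 5-chloro-2-methoxyphenyl in place of hydrogen on an aromatic carbon, para to a large group, gives an at least 4.2-fold lower number from compound 1 to compound 3 (0.63 log units; beyond the scatter). For the compounds shown here, this is the first readable step, and it shows that this position accepts a substituent carrying a six-membered aromatic ring of carbon only, with the effect appearing at smaller amounts of compound. The true size of the step remains unknown and only its floor can be stated, because the value of compound 1 is a limit and not a number: the limit of > 1000 nM in this assay, at which 2 of the 3 values shown sit.

The compounds shown leave open whether the chlorine or the methoxy of the entering group contributes to this step, since an unsubstituted phenyl has no value here. On these data alone, how a carboxylic acid or an amine on the entering ring would read in this assay also remains open.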